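The source may hold more compounds than are shown below. What is called first, only, known or untested is meant among the compounds shown, and "the series" means these compounds.

In an assay on membranes from HeLa cells for displacement of a labelled ligand from adenosine receptor A3 (Homo sapiens), read by scintillation counting, with a stated time of 180 min, tested at 1 uM (on this read-out higher numbers stand for more inhibition at the one concentration tested (going by the name of the read-out) and lower numbers for less inhibition), two compounds built on a shared core have been measured. Compound 1 `CC1=C(C(=O)OCc2ccccc2)C(c2ccoc2)NC(=S)N1` gives 20%. Compound 2 `CC1=C(C(=O)OC(C)(C)C)C(c2ccsc2)NC(=S)N1`, which carries a tert-butyl group on the oxygen next to the carbonyl group, gives 16%. Among these two numbers compound 2 stands lowest, yet its gap to compound 1 lies within the usual scatter of repeated measurements, so the two cannot truly be told apart. Compound 3 `CC1=C(C(=O)OCc2ccccc2)C(c2ccsc2)NC(=S)N1` has not yet been measured. It differs from compound 2 in one place: benzyl in place of tert-butyl on an oxygen next to a carbonyl group. Among the measured compounds shown here, no step between two measured compounds is available to show what this exchange does on its own. Since compound 1 with its benzyl group gives 20% and compound 2 gives 16%, no shift beyond the scatter is expected from the change. The step of a number 2 percentage points higher from compound 2 to compound 3 (within the scatter) is expected to be small. Compound 3 is estimated to give 18%, within a range from 6% to 32%.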

Compound 3, a percentage reported as inhibition, at one concentration (the size of the read-out at that concentration, not a potency): 2%
Compound 3: the middle estimate sits 16 percentage points above what was measured; the whole stated range lies above it.
By their numbers in this assay, from the lowest: compound 3; then compounds 2 and 1 (each within the scatter of the next).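

In this assay, benzyl in place of tert-butyl on an oxygen next to a carbonyl group brings a number 14 percentage points lower from compound 2 to compound 3 (beyond the scatter), so the group at this position can change the reading when thiophen-3-yl is present. Thiophen-3-yl in place of furan-3-yl on a saturated ring carbon, with benzyl kept, brings a number 18 percentage points lower from compound 1 to compound 3 (beyond the scatter), which shows that the ring at that second place also counts; compound 1 and compound 2 differ in two places and could not separate these effects. Nothing measured here gives a reason for either step.

As far as these compounds go, whether the benzyl for tert-butyl exchange acts in the same way when furan-3-yl is present remains open. Also open, from the compounds shown here alone, is how a methyl group or a longer chain such as hexyl on the same oxygen, or a phenyl ring on the saturated ring carbon, would read.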